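This account rests on a few compounds, and the source may have more. Where it says the series, first, only, none or still open, it means among the compounds named here.

Three ureas on a shared core have been run in a functional assay on MGC-803 cells (Homo sapiens) for antiproliferative activity, read by MTT assay, with a stated time of 48 h; a higher number here means a weaker inhibitor, a lower number a stronger inhibitor. Compound 1 `Cc1ccc(NC(=O)Nc2cccc(CNc3nccnc3Cl)c2)cc1C` gives 9870 nM. Compound 2 `O=C(Nc1ccccc1)Nc1cccc(CNc2nccnc2Cl)c1` gives 16300 nM, and compound 3 `Cc1ccccc1NC(=O)Nc1cccc(CNc2nccnc2Cl)c1` gives 14000 nM. All three values sit within the scatter of one another: the steps are a 1.7-fold higher number from compound 1 to compound 2 (0.22 log units; within the scatter), a 1.4-fold higher number from compound 1 to compound 3 (0.15 log units; within the scatter) and a 1.2-fold lower number from compound 2 to compound 3 (0.07 log units; within the scatter). Compound 3 thus lies between compound 2 and compound 1 on the numbers, with no separation beyond the scatter in either direction.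

Compound 4 `COc1ccc(NC(=O)Nc2cccc(CNc3nccnc3Cl)c2)cc1` is the next variation of the same aryl urea terminus, (4-methoxyphenyl in place of 2-methylphenyl on an amide-type nitrogen). Within the data shown here, the steps that bear on this change are the three exchanges of the aryl group already measured, each of which stayed within the scatter, so no step beyond the scatter is expected in this assay when the 2-methylphenyl gives way to the 4-methoxyphenyl. Compound 4 is therefore estimated at 13000 nM, range 6000 nM to 28000 nM, which means an expected step of a 1.1-fold lower number from compound 3 to compound 4 (0.03 log units; within the scatter).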

Compound 4, half-maximal inhibitory concentration: 9240 nM
Compound 4: the middle estimate sits 1.4-fold (0.15 log units) above what was measured, and the stated range covers the measured number.
By their numbers in this assay, from the lowest: compounds 4, 1, 3 and 2 (each within the scatter of the next).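

Exchange of 2-methylphenyl for 4-methoxyphenyl on the amide-type nitrogen puts an oxygen on the aryl terminus for the first time and gives a 1.5-fold lower number from compound 3 to compound 4 (0.18 log units; within the scatter) in this assay with no separation. Methoxy in place of hydrogen on the aromatic carbon gives a 1.8-fold lower number from compound 2 to compound 4 (0.25 log units; within the scatter) and 4-methoxyphenyl in place of 3,4-dimethylphenyl gives a 1.1-fold lower number from compound 1 to compound 4 (0.03 log units; within the scatter) so among these four aryl groups, carrying methyl, methoxy or neither, no step at this nitrogen leaves the scatter. Nothing measured here speaks to a reason for this flat picture.

On these data alone, it remains open whether a carboxylic acid or a dimethylamino group on the phenyl ring, or a longer chain in place of the aryl group, would move the number beyond the scatter. As far as these compounds go, whether changes on the shared core outside the urea terminus would do so also stays open.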